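The compounds below may be only part of what the source reports. "The series", "measured", "known", "first", "only" and "open" are said of these compounds alone.

Measured so far in an assay on CHO cells for displacement of a labelled ligand from adenosine receptor A3 (Homo sapiens), read by scintillation counting, with a stated time of 3 h; on this read-out higher numbers stand for weaker inhibition and lower numbers for stronger inhibition:
compound 1, `CCn1c(-c2ccccc2)nc2c(NC3CCC3)ncnc21`, 84 nM
compound 2, `Cn1c(-c2ccc(C(=O)O)cc2)nc2c(NC3CCCC3)ncnc21`, 25700 nM

Compound 2 carries the higher of the two numbers; compound 1 in this assay gives 84 nM, a far lower value, and the gap between them lies well beyond the scatter. The two compounds differ in more than one place, so the gap cannot be assigned to any single change; it only marks compound 2 as the weaker of the two on this read-out.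

Compound 3, `Cn1c(-c2ccc(Cl)cc2)nc2c(NC3CCCC3)ncnc21`, is not yet measured. It differs from compound 2 in a single place: chloro in place of carboxy on an aromatic carbon. Among the compounds with values here, no measured pair shows this exact change, so its size has to be guessed. Given that compound 2 in this assay gives 25700 nM while the carboxy-free compound 1 gives 84 nM, a large move toward stronger inhibition is expected. The expected step of a 210-fold lower number from compound 2 to compound 3 (2.33 log units; beyond the scatter) is therefore large and downward, beyond the scatter. For compound 3 in this assay the estimate is 120 nM, with a range from 20 nM to 800 nM.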

Compound 3, inhibition constant: 1210 nM
Beside the measured number, compound 3's estimate is 10-fold (1.00 log units) below it, and the stated range ends below it.
By their numbers in this assay, from the lowest: compound 1; then compound 3; then compound 2.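

In this assay, within the data shown here, the exchange of carboxy for chloro on an aromatic carbon para to a large group gives a 21-fold lower number from compound 2 to compound 3 (1.33 log units; beyond the scatter), the first step that can be tied to a single place. This position therefore does not tolerate every group equally, and the read-out responds clearly to what it carries. The step combines the departure of carboxy, with its hydrogen-bond donor and acceptor, and the entry of a single chlorine, and no available data explain its size.

This one pair cannot show whether the change in the number comes from losing carboxy or from gaining chloro, and a compound with only hydrogen at this place, or with an amine, a methoxy or a methyl group, would help separate the two. On these data alone, compound 1 differs from compound 3 in more than one place, so the separate contributions of the ethyl and methyl groups on the ring nitrogen, of the cyclobutyl and cyclopentyl groups on the amine, and of chloro remain open.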